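A Chlorofluorophenyl Swap in a Series Held at Its Limit

This account rests on a few compounds, and the source may have more. Where it says the series, first, only, none or still open, it means among the compounds named here.

Measured in a functional assay on SEM cells (Homo sapiens) for cytotoxicity, with a stated time of 72 h (on this read-out lower numbers stand for an effect already at smaller amounts and higher numbers for an effect only at larger amounts of compound), the compounds read as follows
- compound 1 `CC(C)=CCC[C@@](C)(/C=C/c1ccccc1)/C=C/c1ccc(O)cc1` gives > 36600 nM (a limit)
- compound 2 `C=C[C@@](C)(/C=C/c1ccc(Nc2ccccc2)cc1)CCC=C(C)C` gives > 36600 nM (a limit)
- compound 3 `C=C[C@@](C)(/C=C/c1ccc(Nc2cccc(OC(F)(F)F)c2)cc1)CCC=C(C)C` gives > 36600 nM (a limit)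

Compound 2 has no number to start from, only a limit. The same holds across the series, which shows (the limit of > 36600 nM in this assay, at which 3 of the 3 values shown sit).

Compound 4 `C=C[C@@](C)(/C=C/c1ccc(Nc2ccc(Cl)c(F)c2)cc1)CCC=C(C)C` departs from compound 2 by one change, (4-chloro-3-fluorophenyl in place of phenyl on a nitrogen on an aromatic ring), that is, 4-chloro-3-fluorophenyl in place of phenyl on a nitrogen on an aromatic ring. Among the measured compounds shown here, the only measured step that bears on this change is a step that the two limits leave unreadable from compound 2 to compound 3. That step offers no size to carry over, so no shift beyond the scatter is expected in this assay, in either direction. The expected outcome is a step that the limit leaves unreadable from compound 2 to compound 4. Compound 4 is estimated at 40000 nM, with an expected range of 15000 nM to 80000 nM, and the assay will most likely report only a limit.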

Compound 4, half-maximal effective concentration: > 36600 nM
Compound 4: no number, only a limit; the forecaster's own chance of this, stated with the estimate: 80%; the middle value lies beyond the limit too.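

Among the compounds shown here, compound 2 and compound 4 both give only a limit in this assay, so no step between them can be read. The compounds shown leave open whether 4-chloro-3-fluorophenyl in place of phenyl shifts the effect at all, as the series offers no number to compare: the limit of > 36600 nM in this assay, at which 4 of the 4 values shown sit.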